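From Cyclohexyl to Isopropyl on the Shared Core

This account rests on a few compounds, and the source may have more. Where it says the series, first, only, none or still open, it means among the compounds named here.

Compound 1 `O=C(O)[C@]1(NS(=O)(=O)c2ccc(-n3cc(Cl)cn3)s2)C[C@@H]1C1CCCCC1` has been tested in an assay on isolated protein for inhibition of A disintegrin and metalloproteinase with thrombospondin motifs 5 (Homo sapiens) (a higher number here means a weaker inhibitor, a lower number a stronger inhibitor), where compound 1 gives 360 nM. Among the three measured compounds this is the highest number, so compound 1 is the weakest inhibitor of the set. Compound 3 `O=C(O)[C@]1(NS(=O)(=O)c2ccc(-c3ccc(Cl)cc3)s2)C[C@@H]1c1ccccc1` gives 60 nM in this assay, and compound 2 `C[C@@H]1[C@H](c2ccccc2)[C@]1(NS(=O)(=O)c1ccc(-n2cc(Cl)cn2)s1)C(=O)O` gives 7.4 nM. Both of these carry a phenyl on the core where compound 1 carries a cyclohexyl, but each also differs from compound 1 in another part of the molecule, so none of these pairs isolates a single change.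

Compound 4 `CC(C)[C@H]1C[C@@]1(NS(=O)(=O)c1ccc(-n2cc(Cl)cn2)s1)C(=O)O` keeps everything of compound 1 except one alteration: isopropyl in place of cyclohexyl on a saturated ring carbon. For the measured compounds named here, no measured pair shows this exact change, so its size has to be guessed rather than read off. The expectation is that compound 4 comes out a somewhat weaker inhibitor than compound 1, the estimated step of a 1.7-fold higher number from compound 1 to compound 4 (0.22 log units; within the scatter) being modest and possibly within the scatter. Compound 4 is therefore estimated at 600 nM, with a range from 150 nM to 2500 nM.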

Compound 4, half-maximal inhibitory concentration: 770 nM
Estimate against measurement, compound 4: 1.3-fold (0.11 log units) below, and the stated range covers the measured number.
By their numbers in this assay, from the lowest: compound 2; then compound 3; then compound 1; then compound 4.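

In this assay, for the compounds shown here, isopropyl in place of cyclohexyl is the first change in this set that can be read on its own, and it gives a 2.1-fold higher number from compound 1 to compound 4 (0.33 log units; beyond the scatter) as a modest weakening. At this saturated ring carbon, the group can therefore lose its six-membered ring and drop from 6 heavy atoms to 3 while inhibition falls only slightly. No measurement shown here explains the direction or size of this step.

From the compounds shown here alone, it remains open how an amine or a longer chain such as n-butyl would fare at this position. Also open, going by these compounds, is what phenyl in place of cyclohexyl would do on its own, with everything else in compound 1 kept the same.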